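The source may report more compounds than this note shows. Statements on the series, on what has been measured and on what is new or still open speak of the compounds shown alone.

Compound 1 `COc1cc(N(C)CCN(C)C)c(NC(=O)/C=C\C(C)C)cc1Nc1ncc(C#N)c(-c2cn(C)c3ccccc23)n1` and compound 2 `CCC/C=C\C(=O)Nc1cc(Nc2ncc(C#N)c(-c3cn(C)c4ccccc34)n2)c(OC)cc1N(C)CCN(C)C` share one core and differ only in propyl in place of isopropyl on a double-bonded chain carbon bound to a double-bonded chain carbon. In a functional assay on A549 cells (Homo sapiens) for antiproliferative activity, read by MTT assay, with a stated time of 72 h (on this read-out lower numbers stand for stronger inhibition and higher numbers for weaker inhibition), compound 1 gives 1100 nM and compound 2 gives 166 nM. That is a 6.6-fold lower number from compound 1 to compound 2 (0.82 log units; beyond the scatter), a change well beyond the usual scatter of this kind of measurement. Compound 3 `COc1cc(N(C)CCN(C)C)c(NC(=O)/C=C\C(C)C)cc1Nc1nc(C)cc(-c2cn(C)c3ccccc23)n1` carries a different core; the difference between the two cores is not broken down here. In this assay compound 3 gives 1070 nM, a number within the scatter of compound 1. Compound 4 `CCC/C=C\C(=O)Nc1cc(Nc2nc(C)cc(-c3cn(C)c4ccccc34)n2)c(OC)cc1N(C)CCN(C)C` differs from compound 3 by propyl in place of isopropyl on a double-bonded chain carbon bound to a double-bonded chain carbon, the same change as before. Compound 4 is expected to show a 5.6-fold lower number from compound 3 to compound 4 (0.75 log units; beyond the scatter) in this assay. That expectation rests on compound 1 and the step of a 6.6-fold lower number from compound 1 to compound 2 (0.82 log units; beyond the scatter), since compound 3 starts from a value within the scatter of compound 1. Compound 4 is therefore estimated at 190 nM in this assay, with a range from 75 nM to 500 nM.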

Compound 4, half-maximal inhibitory concentration: 329 nM
Compound 4: middle estimate off by 1.7-fold (0.24 log units), on the low side; the measured number falls inside the stated range.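

In this assay, putting propyl in place of isopropyl on the core of compound 3 gives a 3.3-fold lower number from compound 3 to compound 4 (0.51 log units; beyond the scatter). The change lowers the number on both cores, and the two steps agree as closely as measurements of this kind can tell: the same change on two cores in this assay, a 6.6-fold lower number (0.82 log units; beyond the scatter) from compound 1 to compound 2 and a 3.3-fold lower number (0.51 log units; beyond the scatter) from compound 3 to compound 4, 2.0-fold (0.31 log units) apart, within the scatter of two such steps. This shows that the step carried over between these two cores, but two pairs do not show that it would carry to a further core, nor why propyl gives the lower number.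

The compounds shown leave open how a longer chain such as pentyl, or a chain ending in an amine, would behave at the same place on either core. They also leave open whether the step holds in cells other than these.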